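Amide substituent series against Sgk1 kinase

The source may hold more compounds than are shown below. What is called first, only, known or untested is meant among the compounds shown, and "the series" means these compounds.

Measured compounds:
- compound 1 `CN1CCC(NC(=O)c2cc(-c3ccc(NS(=O)(=O)c4cccc(Cl)c4Cl)cc3)nc3[nH]ncc23)C1`: 21 nM
- compound 2 `NC(=O)c1cc(-c2ccc(NS(=O)(=O)c3cccc(Cl)c3Cl)cc2)nc2[nH]ncc12`: 236 nM
- compound 3 `CC(C)NC(=O)c1cc(-c2ccc(NS(=O)(=O)c3cccc(Cl)c3Cl)cc2)nc2[nH]ncc12`: 17600 nM

In an assay for inhibition of serine/threonine-protein kinase Sgk1 (Homo sapiens), with stated times of 30 min and 60 min, in the presence of a further agent that is not named here (a higher number here means a weaker inhibitor, a lower number a stronger inhibitor), compound 3 gives the highest number of the three, beyond the scatter against both others. The move from compound 1 to compound 3 gave an 840-fold higher number from compound 1 to compound 3 (2.92 log units; beyond the scatter), and the move from compound 2 to compound 3 gave a 75-fold higher number from compound 2 to compound 3 (1.87 log units; beyond the scatter), so the isopropyl on the amide-type nitrogen sits far above the other two groups in this assay.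

Compound 4 `CCN1CCC(CNC(=O)c2cc(-c3ccc(NS(=O)(=O)c4cccc(Cl)c4Cl)cc3)nc3[nH]ncc23)C1` has not yet been measured. It differs from compound 3 by (1-ethylpyrrolidin-3-yl)methyl in place of isopropyl on an amide-type nitrogen. The step that bears on this most directly is an 840-fold higher number from compound 1 to compound 3 (2.92 log units; beyond the scatter), which runs the other way: replacing a ring-bearing amide substituent with isopropyl raised the number greatly. Within the data shown here, compound 4 returns a ring-bearing substituent, now carried one carbon further from the nitrogen and with ethyl instead of methyl on the ring nitrogen; no measured pair speaks to either of these smaller differences. A large fall in the number is therefore expected, of about a 250-fold lower number from compound 3 to compound 4 (2.40 log units; beyond the scatter), though not necessarily all the way back to compound 1. Compound 4 is estimated at 70 nM, within 15 nM to 400 nM.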

Compound 4, half-maximal inhibitory concentration: 109 nM
The estimate for compound 4 lay 1.6-fold (0.19 log units) below the measured number; the measured number falls inside the stated range.
By their numbers in this assay, from the lowest: compound 1; then compound 4; then compound 2; then compound 3.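

In this assay, (1-ethylpyrrolidin-3-yl)methyl on the amide-type nitrogen recovers most of what isopropyl loses, with a 160-fold lower number from compound 3 to compound 4 (2.21 log units; beyond the scatter), so compound 1 is no longer the only substituted amide here with a number below that of the unsubstituted amide. The gain over hydrogen is modest, at a 2.2-fold lower number from compound 2 to compound 4 (0.34 log units; beyond the scatter), and 1-methylpyrrolidin-3-yl remains ahead, with a 5.2-fold higher number from compound 1 to compound 4 (0.72 log units; beyond the scatter); since isopropyl lies above hydrogen and both pyrrolidine-bearing groups below it, heavy-atom count alone does not order these substituents. Nothing available accounts for these steps.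

The last step combines the added methylene link with ethyl in place of methyl on the ring nitrogen, and the two changes cannot be separated here. Also open, from the compounds shown here alone, is whether the ring nitrogen matters, which a cyclopentyl group or an open-chain dimethylaminoethyl group on the amide-type nitrogen would test.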